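A few compounds are considered here, and "the series" means these few. Any claim that something is new, unique, unknown or untested is made for them only; others in the source may bear on it.

The measured compounds:

Compound 1 `COc1cc(-c2nn(-c3cccc(NC(=O)Nc4cc(C(F)(F)F)cc(C(F)(F)F)c4)c3)cc2-c2ccncc2)ccc1Cl` gives 931 nM in a functional assay on HCC 2998 cells (Homo sapiens) for inhibition, read by sulforhodamine B assay, with a stated time of 48 h; on this read-out lower numbers stand for stronger inhibition of growth and higher numbers for weaker inhibition of growth.
Compound 2 `COc1cc(-c2nn(-c3cccc(NC(=O)Nc4ccc(Cl)c(Cl)c4)c3)cc2-c2ccncc2)ccc1Cl` gives 1560 nM in this assay.
Compound 3 `O=C(Nc1cccc(-n2cc(-c3ccncc3)c(-c3ccc(Cl)c(O)c3)n2)c1)Nc1ccc(Cl)c(Cl)c1` gives 2890 nM in this assay.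

Compounds 2 and 3 share one core, and compound 3 carries the change (hydrogen in place of methyl on an oxygen on an aromatic ring). The step this change made was a 1.9-fold higher number from compound 2 to compound 3 (0.27 log units; within the scatter). Compounds 1 and 2 differ in more than one place; the difference between their two cores is not broken down here. The values of compound 1 and compound 2 lie within the scatter of each other, while the gap from compound 1 to compound 3 lies beyond it.

Within the data shown here, compound 4 `O=C(Nc1cccc(-n2cc(-c3ccncc3)c(-c3ccc(Cl)c(O)c3)n2)c1)Nc1cc(C(F)(F)F)cc(C(F)(F)F)c1` is related to compound 1 by hydrogen in place of methyl on an oxygen on an aromatic ring, the same change as the one from compound 2 to compound 3, made on the same place. The expectation for compound 4 rests on the step of a 1.9-fold higher number from compound 2 to compound 3 (0.27 log units; within the scatter), carried over to the core of compound 1. Compound 4 is therefore expected to show a 1.9-fold higher number from compound 1 to compound 4 (0.27 log units; within the scatter) in this assay. The estimated value for compound 4 is 1750 nM, with the range expected to run from 800 nM to 3900 nM.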

Compound 4, concentration for 50% growth inhibition: 1030 nM
The estimate for compound 4 lay 1.7-fold (0.23 log units) above the measured number, within the range that was stated.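

In this assay the swap of methoxy to hydroxy on the core of compound 1 gave a 1.1-fold higher number from compound 1 to compound 4 (0.04 log units; within the scatter) and so stayed within the scatter. Within these two pairs the change carried over from one core to the other without a difference that can be told from scatter: the same change on two cores in this assay, a 1.9-fold higher number (0.27 log units; within the scatter) from compound 2 to compound 3 and a 1.1-fold higher number (0.04 log units; within the scatter) from compound 1 to compound 4, 1.7-fold (0.22 log units) apart, within the scatter of two such steps. This does not show that the change has a real effect on growth inhibition on either core, since each step is itself within the scatter, and it says nothing about any core beyond these two.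

As far as these compounds go, only methoxy and hydroxy appear at this place on the 4-chloro-3-methoxyphenyl group, so what an ethoxy group, an amine or a carboxylic acid there would do remains open. Also open, from the compounds shown here alone, is whether the swap would stay as small on a core carrying a nitrile in place of the trifluoromethyl groups.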